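Adding trifluoromethyl to the 4-cyanophenyl ether

This account rests on a few compounds, and the source may have more. Where it says the series, first, only, none or still open, it means among the compounds named here.

Compound 1 `CC(O)(COc1cccc(C(F)(F)F)c1)C(=O)Nc1ccc(S(F)(F)(F)(F)F)cc1`: 21900 nM
Compound 2 `CC(O)(COc1ccccc1C(F)(F)F)C(=O)Nc1ccc(S(F)(F)(F)(F)F)cc1`: 7100 nM
Compound 3 `CC(O)(COc1ccc(C#N)cc1)C(=O)Nc1ccc(S(F)(F)(F)(F)F)cc1`: 32200 nM

These three values come from a functional assay on DU-145 cells (Homo sapiens) for antiproliferative activity, read by propidium iodide staining, with a stated time of 96 h (a lower number here means a stronger inhibitor, a higher number a weaker inhibitor), and share the core of compound 1, differing only in the aryl group on the ether oxygen. Compound 3 cannot be told apart from compound 1, with a 1.5-fold higher number from compound 1 to compound 3 (0.17 log units; within the scatter) between them. Compound 2 stands apart from it, with a 4.5-fold higher number from compound 2 to compound 3 (0.66 log units; beyond the scatter) as the measured step.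

Compound 4 `CC(O)(COc1ccc(C#N)cc1C(F)(F)F)C(=O)Nc1ccc(S(F)(F)(F)(F)F)cc1` follows from compound 3 through trifluoromethyl in place of hydrogen on an aromatic carbon and so has trifluoromethyl in place of hydrogen on an aromatic carbon, ortho to a large group and meta to a cyano group. For the measured compounds named here, no measured step makes this exact change, and no measured compound carries both groups. The closest evidence is compound 2, which has the 2-(trifluoromethyl)phenyl group. It gave a 3.1-fold lower number from compound 1 to compound 2 (0.49 log units; beyond the scatter) against the 3-(trifluoromethyl)phenyl group, and the step to the 4-cyanophenyl group was also modest. A modest move to a lower number therefore seems likely, though this is uncertain.

The expected change is a 3.2-fold lower number from compound 3 to compound 4 (0.51 log units; beyond the scatter) in this assay as an estimate. Compound 4 is expected at 10000 nM with an estimated range of 3500 nM to 30000 nM before any measurement.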

Compound 4, half-maximal inhibitory concentration: 21200 nM
Estimate against measurement, compound 4: 2.1-fold (0.33 log units) below, and the stated range covers the measured number.
By their numbers in this assay, from the lowest: compound 2; then compounds 4, 1 and 3 (each within the scatter of the next).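

In this assay, for the compounds shown here, trifluoromethyl on an aromatic carbon, ortho to a large group and meta to a cyano group, gives no step that can be told from the scatter, with a 1.5-fold lower number from compound 3 to compound 4 (0.18 log units; within the scatter). Read from the other side, cyano in place of hydrogen on the aromatic ring of compound 2 does give a resolved modest step, a 3.0-fold higher number from compound 2 to compound 4 (0.48 log units; beyond the scatter), so the lower number of compound 2 does not persist once the cyano group is also on the ring. Nothing given here accounts for why the cyano group has this effect on compound 2 while trifluoromethyl leaves compound 3 within the scatter.

These compounds form a single pair of steps around compound 4, so they leave open whether the same reading would hold with another group in place of trifluoromethyl at this position, such as a chlorine atom or a methyl group. They also leave open whether an amine or a carboxylic acid in place of the cyano group would keep the number of compound 2 or move it as the cyano group does.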